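A few compounds are considered here, and "the series" means these few. Any claim that something is new, unique, unknown or untested is made for them only; others in the source may bear on it.

Measured compounds:

Compound 1, `COc1cc2c(Oc3ccc(NC(=O)c4nn(-c5ccccc5C)c(=O)cc4C)cc3F)ccnc2cc1OCCCN1CCCCC1`, gives 2500 nM in a functional assay on U-87MG ATCC cells (Homo sapiens) for inhibition, read by MTT assay, with a stated time of 72 h; on this read-out lower numbers stand for stronger inhibition and higher numbers for weaker inhibition.
Compound 2, `COc1cc2c(Oc3ccc(NC(=O)c4nn(-c5ccccc5C(F)(F)F)c(=O)cc4C)cc3F)ccnc2cc1OCCCN1CCCCC1`, gives 1150 nM in this assay.
Compound 3, `COc1cc2c(Oc3ccc(NC(=O)c4nn(-c5ccccc5OC(F)(F)F)c(=O)cc4C)cc3F)ccnc2cc1OCCCN1CCCC1`, gives 1280 nM in this assay.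

Compound 3 stands second highest of the three numbers; its value and that of compound 2 lie within the scatter of each other, while compound 1 sits somewhat higher, though still within the scatter of compound 3. Among the compounds with values here, the only measured step that is beyond the scatter, a 2.2-fold lower number from compound 1 to compound 2 (0.34 log units; beyond the scatter), concerns a change on the aromatic ring and does not touch the saturated chain.

Compound 4, `COc1cc2c(Oc3ccc(NC(=O)c4nn(-c5ccccc5OC(F)(F)F)c(=O)cc4C)cc3F)ccnc2cc1OCCCN1CCCCC1`, differs from compound 3 by piperidin-1-yl in place of pyrrolidin-1-yl on a saturated chain carbon, three bonds along the chain from an oxygen on an aromatic ring. Within the data shown here, no measured step isolates this ring change: compound 2 and compound 3 differ in two places at once, so their near-identical values give only an indirect hint that the chain end matters little here. The expectation is therefore a step of a 1.1-fold lower number from compound 3 to compound 4 (0.03 log units; within the scatter), that is, none beyond the scatter. Compound 4 is estimated at 1200 nM in this assay, within a range from 600 nM to 2400 nM.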

Compound 4, half-maximal inhibitory concentration: 1300 nM
Compound 4: middle estimate off by 1.1-fold (0.03 log units), on the low side, within the range that was stated.
By their numbers in this assay, from the lowest: compounds 2, 3, 4 and 1 (each within the scatter of the next, the first and the last beyond it).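

In this assay, within the data shown here, piperidin-1-yl in place of pyrrolidin-1-yl at the end of the chain gives a 1.0-fold higher number from compound 3 to compound 4 (0.01 log units; within the scatter), the first direct reading at this place: for this pair, the six-membered ring and the five-membered ring cannot be told apart. Among these compounds, on the aromatic carbon, trifluoromethoxy in place of trifluoromethyl gives a 1.1-fold higher number from compound 2 to compound 4 (0.05 log units; within the scatter), and trifluoromethoxy in place of methyl gives a 1.9-fold lower number from compound 1 to compound 4 (0.28 log units; within the scatter), so only the step from methyl to trifluoromethyl, a 2.2-fold lower number from compound 1 to compound 2 (0.34 log units; beyond the scatter), lies beyond the scatter. Nothing available offers a reason for these steps.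

Going by these compounds, whether a morpholin-4-yl group or a dimethylamino group would read the same at the chain end remains open. So does the effect of a shorter chain, such as 2-(piperidin-1-yl)ethyl, and whether the ring swap behaves alike with methyl or trifluoromethyl on the aromatic carbon.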